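Removing a Chloro Group from a Weak Growth Inhibitor

This account rests on a few compounds, and the source may have more. Where it says the series, first, only, none or still open, it means among the compounds named here.

Compound 2 `O=C(Nc1ccc(Oc2ccc(-c3nccs3)cc2)cc1)Nc1cc(C(F)(F)F)ccc1Cl` and compound 1 `O=C(Nc1ccc(Oc2ccc(-c3nccs3)cc2)cc1)Nc1cccc(C(F)(F)F)c1` share one core, while compound 3 `O=C(Nc1ccc(Cl)cc1)Nc1ccc(Oc2ccc(-c3ncc[nH]3)cc2)cc1` is built on another; the difference between the two cores is not broken down here. In a functional assay on A549 cells (Homo sapiens) for inhibition, read by MTT assay and WST assay, with a stated time of 72 h, tested at 10 uM (on this read-out higher numbers stand for more inhibition of growth at the one concentration tested and lower numbers for less inhibition of growth), compound 2 gives 75.5% and compound 1 gives 71.5%. The step of a number 4 percentage points lower from compound 2 to compound 1 (within the scatter) came from hydrogen in place of chloro on an aromatic carbon. In this assay compound 3 gives 8.86%, far apart from both. Compound 4 `O=C(Nc1ccccc1)Nc1ccc(Oc2ccc(-c3ncc[nH]3)cc2)cc1` arises from compound 3 by hydrogen in place of chloro on an aromatic carbon, the same kind of change, though here the place is para to a large group, whereas earlier it was ortho to a large group and para to a trifluoromethyl group. The earlier step of a number 4 percentage points lower from compound 2 to compound 1 (within the scatter) stayed within the scatter. On that basis the step of a number 0.9 percentage points lower from compound 3 to compound 4 (within the scatter) is expected to be small as well. Compound 4 is therefore estimated at 8%, with a range from -3% to 22%.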

Compound 4, percent growth inhibition at one concentration: 7.09%
Compound 4: the middle estimate sits 0.9 percentage points above what was measured, within the range that was stated.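

In this assay the change from chloro to hydrogen gives a number 1.8 percentage points lower from compound 3 to compound 4 (within the scatter), and it carries from one core to the other with no difference that can be told apart from the scatter: the same change on two cores in this assay, a number 4 percentage points lower (within the scatter) from compound 2 to compound 1 and a number 1.8 percentage points lower (within the scatter) from compound 3 to compound 4, 2.2 percentage points apart, within the scatter of two such steps So, on these two cores, removing the chloro group leaves the number within the scatter, whether the number is high or low. Within the data shown here, this does not show that the same would hold on another core or at another place on the ring, as each core offers only one pair and the place of the change differs between the two.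

The compounds shown leave open what other groups would do at these places. An amine or a carboxylic acid in place of chloro could behave differently on either core.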